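Working notes: compound 1 to compound 3 in this assay

A few compounds are considered here, and "the series" means these few. Any claim that something is new, unique, unknown or untested is made for them only; others in the source may bear on it.

Measured so far:
compound 1 `O=C(NN=C1C(Cl)=C(Cl)C(Cl)=C1Cl)c1ccccc1` — 800 nM
compound 2 `ClC1=C(Cl)C(Cl)=C(Cl)C1=NNC1CCCCC1` — > 3000 nM

Within the data shown here, in a functional assay on MM1.S cells (Homo sapiens) for cytotoxicity, read by MTT assay, with a stated time of 48 h (a lower number here means a stronger inhibitor, a higher number a weaker inhibitor), compound 1 gives 800 nM, and this is the only number reported for the series. Compound 2 shows only a limit of the assay, > 3000 nM, so no number stands for it; the situation is the limit of > 3000 nM in this assay, at which 1 of the 2 values shown sits. Among the measured compounds shown here, compound 1 therefore stands alone as the one compound with a measured value, and no step between measured compounds is available.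

Compound 3 `CC(C)(C)C(=O)NN=C1C(Cl)=C(Cl)C(Cl)=C1Cl` is not yet measured. It differs from compound 1 in one place: tert-butyl in place of phenyl on a carbonyl carbon. For the measured compounds named here, no measured pair shows a change of this kind, so the size of the step is unknown; a step not larger than the usual scatter is expected, and if anything a slight loss. For compound 3 the expected value in this assay is 1000 nM, between 400 nM and 3000 nM, which corresponds to an estimated step of a 1.3-fold higher number from compound 1 to compound 3 (0.10 log units; within the scatter).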

Compound 3, half-maximal inhibitory concentration: 2000 nM
Compound 3: middle estimate off by 2.0-fold (0.30 log units), on the low side; the range from low to high includes it.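

Among these compounds, replacing phenyl with tert-butyl on a carbonyl carbon gives the first readable step in this assay: a 2.5-fold higher number from compound 1 to compound 3 (0.40 log units; beyond the scatter). The aromatic ring at this position can therefore be removed with only a modest loss, and compound 3 still gives a measured value without any ring on the carbonyl carbon. Compound 2 remains a limit of the assay rather than a number, so it provides no step to set beside this one: the limit of > 3000 nM in this assay, at which 1 of the 3 values shown sits.

With only phenyl and tert-butyl compared on this carbonyl carbon, the two groups cannot show whether the ring itself or some other difference between them accounts for the step. As far as these compounds go, it also remains open how a pyridine ring, a straight butyl chain or a phenyl carrying an amine would compare at this position on the shared core.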